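A phenyl for a methyl at the assay limit

The source may hold more compounds than are shown below. What is called first, only, known or untested is meant among the compounds shown, and "the series" means these compounds.

In a functional assay on HepG2 cells (Homo sapiens) for cytotoxicity, read by MTT assay, with a stated time of 72 h (on this read-out higher numbers stand for weaker inhibition and lower numbers for stronger inhibition), compound 1 (`COC(=O)c1ccc(-n2cc(CCCOS(=O)(=O)c3ccc(C)cc3)nn2)cc1`) gives > 100000 nM as a limit, not a number. Compound 2 (`COc1ccc(-n2cc(CCCOS(=O)(=O)c3ccc(C)cc3)nn2)cc1`) gives > 100000 nM as a limit too. Going by the values given here, both sit at the same limit (the limit of > 100000 nM in this assay, at which 2 of the 2 values shown sit), so the one measured change (a step that the two limits leave unreadable from compound 1 to compound 2) gives no size to carry over. Compound 3 (`COC(=O)c1ccc(-n2cc(CCCOS(=O)(=O)c3ccc(-c4ccccc4)cc3)nn2)cc1`) has phenyl in place of methyl on an aromatic carbon of compound 1 (phenyl in place of methyl on an aromatic carbon). Only a small step (an at least 1.4-fold lower number from compound 1 to compound 3 (0.15 log units; that floor lies within the scatter)) is expected, towards stronger inhibition if any shows. Compound 3 is expected near 70000 nM in this assay, with an estimated range from 20000 nM to 200000 nM overall.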

Compound 3, half-maximal inhibitory concentration: 46200 nM
Compound 3: middle estimate off by 1.5-fold (0.18 log units), on the high side; the measured number falls inside the stated range.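

In this assay, phenyl in place of methyl on an aromatic carbon, para to a large group, gives an at least 2.1-fold lower number from compound 1 to compound 3 (0.33 log units; beyond the scatter), so a change at this position has a readable result. Going by these compounds alone, the step from compound 1 to compound 2 cannot be read, which leaves this as the only readable change so far. The printed size is only a floor, because compound 1 starts from a limit: the limit of > 100000 nM in this assay, at which 2 of the 3 values shown sit.

From the compounds shown here alone, whether an amine or a carboxylic acid at this position would also give a readable step stays open. So does whether phenyl would give a similar step on compound 2.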